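A Methoxy Returns in Place of Fluoro

The source may report more compounds than this note shows. Statements on the series, on what has been measured and on what is new or still open speak of the compounds shown alone.

Going by the values given here, compound 2 `Nc1cc(N)c2nc(-c3ccccc3)c(NCc3ccc(F)cc3)nc2c1` gives 4070 nM in a functional assay on NCI-H460 cells (Homo sapiens) for inhibition, read by sulforhodamine B assay, with a stated time of 48 h (on this read-out higher numbers stand for weaker inhibition of growth and lower numbers for stronger inhibition of growth), the lowest of the two numbers measured so far, while compound 1 `COc1ccc(CNc2nc3cc(N)cc(N)c3nc2-c2ccccc2)cc1OC` gives 24000 nM. Compound 3 `COc1ccc(CNc2nc3cc(N)cc(N)c3nc2-c2ccccc2)cc1` differs from compound 2 by methoxy in place of fluoro on an aromatic carbon, on an aromatic carbon of a six-membered aromatic ring of carbon only, para to a large group. Among the compounds with values here, one measured step bears on this change: a 5.9-fold lower number from compound 1 to compound 2 (0.77 log units; beyond the scatter), where two methoxy groups left and fluoro entered. Compound 3 keeps one methoxy, so a partial reversal of that step is expected. Compound 3 is therefore estimated at 9000 nM, within 3500 nM to 25000 nM, an expected step of a 2.2-fold higher number from compound 2 to compound 3 (0.34 log units; beyond the scatter) toward weaker inhibition.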

Compound 3, concentration for 50% growth inhibition: 20400 nM
Beside the measured number, compound 3's estimate is 2.3-fold (0.36 log units) below it, within the range that was stated.
By their numbers in this assay, from the lowest: compound 2; then compounds 3 and 1 (each within the scatter of the next).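

In this assay the exchange of fluoro for a single methoxy, para to a large group, is enough to weaken growth inhibition, with a 5.0-fold higher number from compound 2 to compound 3 (0.70 log units; beyond the scatter) as the step. The second methoxy of compound 1 adds nothing that can be read, as a 1.2-fold lower number from compound 1 to compound 3 (0.07 log units; within the scatter) shows, so the difference among these compounds follows the group at this one carbon. Nothing in the data accounts for this difference between fluoro and methoxy.

Going by these compounds, it remains open whether hydrogen, chloro, an amine or a carboxylic acid on this carbon would give numbers closer to those of compound 2 or compound 3.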